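The compounds below may be only part of what the source reports. "The series", "measured", "known", "first", "only" and "open" are said of these compounds alone.

Values in a functional assay on Huh-7 cells (Homo sapiens) for antiproliferative activity, read by CCK-8 assay, with a stated time of 72 h (a lower number here means a stronger inhibitor of growth, a higher number a weaker inhibitor of growth), so far
compound 1 `CCC1C(=O)N(C)c2cnc(-n3ccc4cc(C(=O)NC)ccc43)nc2N1c1ccn(C)n1` gives 13200 nM
compound 2 `CC[C@@H]1C(=O)N(C)c2cnc(Nc3ccc(S(=O)(=O)Nc4ccccc4)cc3)nc2N1C1CCCC1` gives 2790 nM
compound 3 `CC[C@@H]1C(=O)N(C)c2cnc(Nc3ccc(S(=O)(=O)NCCCO)cc3)nc2N1C1CCCC1` gives 262 nM

Compound 1 has the highest number of the three and is the weakest inhibitor of growth among them. Compound 4 `CCCCNC(=O)c1ccc2c(ccn2-c2ncc3c(n2)N(c2ccn(C)n2)C(CC)C(=O)N3C)c1` keeps the core of compound 1 and differs by propyl in place of hydrogen on a saturated chain carbon bound to an amide-type nitrogen, which turns methylcarbamoyl into butylcarbamoyl. Within the data shown here, only one measured step bears on this, and only loosely. an 11-fold lower number from compound 2 to compound 3 (1.03 log units; beyond the scatter) is large, but it puts 3-hydroxypropyl in place of phenyl on a sulfonamide nitrogen, not on an amide-type nitrogen. Among the measured compounds shown here, no measured step makes this change on the core of compound 1, so no step beyond the scatter is expected. The estimated step is a 1.5-fold lower number from compound 1 to compound 4 (0.17 log units; within the scatter) in this assay. Compound 4 is expected at 9000 nM, in a range from 3000 nM to 25000 nM.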

Compound 4, concentration for 50% growth inhibition: 8670 nM
Beside the measured number, compound 4's estimate is 1.0-fold (0.02 log units) above it; low and high end bracket the measured number.
By their numbers in this assay, from the lowest: compound 3; then compound 2; then compounds 4 and 1 (each within the scatter of the next).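

In this assay the change from methylcarbamoyl to butylcarbamoyl gives a 1.5-fold lower number from compound 1 to compound 4 (0.18 log units; within the scatter) and so shows that, on the core of compound 1, this amide-type nitrogen carries butyl as well as methyl without a step beyond the scatter. Among these compounds, the only earlier step, an 11-fold lower number from compound 2 to compound 3 (1.03 log units; beyond the scatter) on a sulfonamide nitrogen, was large, and a step of that size is not seen with this change. No evidence is available that would explain this result. As far as these compounds go, what stays open is whether a longer chain on this nitrogen would shift the number, and whether an amine or a carboxylic acid at the end of the chain would do so.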